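The source may report more compounds than this note shows. Statements on the series, on what has been measured and on what is new or still open speak of the compounds shown alone.

Among the measured compounds shown here, compound 2 `COc1cc(C(F)(F)F)cc(SC)c1C(=O)NC1(c2cccnc2)CCCN(C)C1` gives the highest of the two numbers measured so far in an assay on cells for inhibition of sodium- and chloride-dependent glycine transporter 1 (Homo sapiens) (on this read-out higher numbers stand for an effect only at larger amounts of compound and lower numbers for an effect already at smaller amounts), at 54 nM; compound 1 `COc1cc(C(F)(F)F)cc(SC)c1C(=O)NC1(c2cccc(Cl)c2)CCCN(C)C1` gives 25 nM, and a 2.2-fold higher number from compound 1 to compound 2 (0.33 log units; beyond the scatter). Compound 3 `COc1cc(C(F)(F)F)cc(SC)c1C(=O)NC1(c2ncccn2)CCCN(C)C1` differs from compound 2 in one place: pyrimidin-2-yl in place of pyridin-3-yl on a saturated ring carbon. For the measured compounds named here, only that one measured step bears on this change, and it also exchanged one ring for another on the same saturated ring carbon, moving the number modestly upward. Compound 3 is therefore expected to give a somewhat higher number again, a 1.9-fold higher number from compound 2 to compound 3 (0.27 log units; within the scatter). In this assay compound 3 is estimated at 100 nM, with a likely range from 40 nM to 250 nM.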

Compound 3, half-maximal effective concentration: > 10000 nM
Compound 3: a limit, no number (the forecaster's own chance of this, stated with the estimate: 5%); middle value at least 100-fold (2.00 log units) from the limit.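

Which ring sits on this saturated ring carbon matters far more than the earlier compounds showed: pyridin-3-yl in place of 3-chlorophenyl gave only a 2.2-fold higher number from compound 1 to compound 2 (0.33 log units; beyond the scatter). Pyrimidin-2-yl instead brings an at least 180-fold higher number from compound 2 to compound 3 (2.26 log units; beyond the scatter), and compared with 3-chlorophenyl it brings an at least 400-fold higher number from compound 1 to compound 3 (2.60 log units; beyond the scatter). Compound 3 gives a limit of the assay, not a number: the limit of > 10000 nM in this assay, at which 1 of the 3 values shown sits.

The compounds shown leave open whether the loss follows from the added ring nitrogen itself or from where the ring nitrogens lie. Pyridin-2-yl or pyrimidin-5-yl on the same carbon would help separate these two possibilities.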